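This account rests on a few compounds, and the source may have more. Where it says the series, first, only, none or still open, it means among the compounds named here.

Compound 1 `COc1cc(-c2nc(-c3ccccc3)[nH]c2-c2ccnc(NCCCNS(=O)(=O)c3ccc(Cl)cc3)n2)ccc1F` gives 83100 nM in a functional assay on LOX IMVI cells (Homo sapiens) for cytotoxicity, read by MTT assay, with a stated time of 24 h; a higher number here means a weaker inhibitor, a lower number a stronger inhibitor.
Compound 2 `COc1cc(-c2nc(-c3ccccc3)[nH]c2-c2ccnc(NCCCNS(=O)(=O)c3ccc(Br)cc3)n2)ccc1F` gives 33900 nM.
Compound 3 `COc1cc(-c2nc(-c3ccccc3)[nH]c2-c2ccnc(NCCCNS(=O)(=O)c3ccc(C)cc3)n2)ccc1F` gives 2590 nM.

Compound 2 stands second highest of the three numbers: its nearest neighbour is compound 1, with a 2.5-fold lower number from compound 1 to compound 2 (0.39 log units; beyond the scatter), and its furthest is compound 3, with a 13-fold lower number from compound 2 to compound 3 (1.12 log units; beyond the scatter). Compound 4 `COc1ccc(S(=O)(=O)NCCCNc2nccc(-c3[nH]c(-c4ccccc4)nc3-c3ccc(F)c(OC)c3)n2)cc1` differs from compound 2 by methoxy in place of bromo on an aromatic carbon. Among the compounds with values here, the steps that bear on it are the exchanges of the halogen for methyl, a 32-fold lower number from compound 1 to compound 3 (1.51 log units; beyond the scatter) and a 13-fold lower number from compound 2 to compound 3 (1.12 log units; beyond the scatter), both large, while the halogen swap a 2.5-fold lower number from compound 1 to compound 2 (0.39 log units; beyond the scatter) was modest. Within the data shown here, no measured step involves methoxy, so the direction is taken from the methyl steps but with less confidence in size. The expected step is a 3.8-fold lower number from compound 2 to compound 4 (0.58 log units; beyond the scatter). Compound 4 is estimated at 9000 nM, with a range from 1500 nM to 50000 nM.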

Compound 4, half-maximal inhibitory concentration: 6130 nM
Compound 4: the middle estimate sits 1.5-fold (0.17 log units) above what was measured; the range from low to high includes it.
By their numbers in this assay, from the lowest: compound 3; then compound 4; then compound 2; then compound 1.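

Methoxy, the only group at this place that carries oxygen, also gives a lower number than either halogen (a 5.5-fold lower number from compound 2 to compound 4 (0.74 log units; beyond the scatter)) (a 14-fold lower number from compound 1 to compound 4 (1.13 log units; beyond the scatter)). It does not match methyl, however (a 2.4-fold higher number from compound 3 to compound 4 (0.37 log units; beyond the scatter)), so the two groups that replace the halogens differ from each other beyond the scatter. Nothing available explains this order. Going by these compounds, whether it would extend to an amine or a carboxylic acid at this place, or to a longer chain in place of methoxy, stays open.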